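Methyl on the lactam ring: solubility of compound 4

This account rests on a few compounds, and the source may have more. Where it says the series, first, only, none or still open, it means among the compounds named here.

Measured so far:
compound 1 `CNC(=O)c1cc(-c2cnc(NCc3c(F)ccc4c3CCO4)c3cn[nH]c(=O)c23)n(C)n1` gives 7000 nM
compound 2 `O=C1CCCN1c1cnc(NCc2c(F)ccc3c2CCO3)n2cnnc12` gives 640000 nM
compound 3 `Cn1nccc1-c1cnc(NCc2c(F)ccc3c2CCO3)c2cn[nH]c(=O)c12` gives 2000 nM

In a physicochemical assay for solubility, read by LC-MS, in phosphate buffer, with a stated time of 24 h, at pH 7.4 (on this read-out higher numbers stand for higher solubility and lower numbers for lower solubility), compound 2 stands highest of the three numbers; compound 1 sits next, and compound 3 furthest away. For the measured compounds named here, the only step among measured compounds that differ in one place, a 3.5-fold lower number from compound 1 to compound 3 (0.54 log units; beyond the scatter), concerns hydrogen in place of methylcarbamoyl on an aromatic carbon of the core shared by compound 1 and compound 3, a core compound 2 does not share. Compound 4 `C[C@@H]1CC(=O)N(c2cnc(NCc3c(F)ccc4c3CCO4)n3cnnc23)C1` differs from compound 2 by methyl in place of hydrogen on a saturated ring carbon, turning 2-oxopyrrolidin-1-yl into 4-methyl-2-oxopyrrolidin-1-yl. Going by the values given here, no measured step covers this change, so the expectation rests on the change being small and the number of compound 2 being high. A slight downward step is expected, a 1.6-fold lower number from compound 2 to compound 4 (0.20 log units; within the scatter), close to or within the scatter. Compound 4 is therefore estimated at 400000 nM, with a range from 150000 nM to 1000000 nM.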

Compound 4, solubility: 130000 nM
Compound 4: the middle estimate sits 3.1-fold (0.49 log units) above what was measured; the measured number lies below the stated range.
By their numbers in this assay, from the lowest: compound 3; then compound 1; then compound 4; then compound 2.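

In this assay, methyl in place of hydrogen on a saturated ring carbon, two ring bonds from the ring nitrogen, brings a 4.9-fold lower number from compound 2 to compound 4 (0.69 log units; beyond the scatter) and so this one added carbon moves the number beyond the scatter. For the compounds shown here, this is the first measured step on the 2-oxopyrrolidin-1-yl ring, whereas the only earlier step concerned a different place on a different core. Nothing measured here accounts for the size of this step.

As far as these compounds go, it remains open whether the mirror-image form of the methyl compound, or an ethyl group, a hydroxyl group or an amine on the same ring carbon, would shift the number by a similar amount. The compounds shown also leave open how a methyl on any other carbon of this ring would read.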